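Trimming the Sulfur Chain in a Quinazoline Series

The compounds below may be only part of what the source reports. "The series", "measured", "known", "first", "only" and "open" are said of these compounds alone.

Measured so far:
Compound 1 `CCCCC[Se]c1nc(NCc2ccccc2)c2ccccc2n1` — 72700 nM
Compound 2 `CCCCCSc1nc(NCc2ccc([Se]C)cc2)c2ccccc2n1` — 14400 nM
Compound 3 `COc1ccc(CNc2nc(S)nc3ccccc23)cc1` — 6490 nM

Of the compounds shown here, three sharing one core have been tested in a functional assay on HT-29 cells (Homo sapiens) for cytotoxicity, read by MTT assay, with a stated time of 72 h; on this read-out lower numbers stand for stronger inhibition of growth and higher numbers for weaker inhibition of growth. Compound 1 `CCCCC[Se]c1nc(NCc2ccccc2)c2ccccc2n1` gives 72700 nM, compound 2 `CCCCCSc1nc(NCc2ccc([Se]C)cc2)c2ccccc2n1` gives 14400 nM, and compound 3 `COc1ccc(CNc2nc(S)nc3ccccc23)cc1` gives 6490 nM. On these three numbers compound 2 stands second highest. Its nearest neighbour is compound 3, whose number is lower by a margin beyond the usual scatter; the furthest is compound 1, whose number is higher, again beyond the scatter. No two of these compounds differ in a single place, so no measured step can be drawn among them.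

Compound 4 `CSc1nc(NCc2ccc([Se]C)cc2)c2ccccc2n1` is the next compound, not yet measured in this assay. It differs from compound 2 in one place: hydrogen in place of butyl on a saturated chain carbon bound to a sulfur. Read one bond further out, the change is pentylsulfanyl to methylsulfanyl.

Going by the values given here, with no measured step to lean on, the account can only note that compound 3, which carries no alkyl chain on its sulfur, shows the lowest number at 6490 nM, while compound 1, with a longer chain on selenium, shows the highest at 72700 nM. On that basis a small step is expected from compound 2 to compound 4 in this assay, toward a lower number, though it may well stay within the scatter, and the expected step is a 1.2-fold lower number from compound 2 to compound 4 (0.08 log units; within the scatter). Compound 4 is therefore estimated at 12000 nM, with a range from 4000 nM to 40000 nM.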

Compound 4, concentration for 50% growth inhibition: > 100000 nM
Compound 4 ended at the assay's limit; the forecaster's own chance of this, stated with the estimate: 5%; at least 8.3-fold (0.92 log units) between middle value and limit.
By their numbers in this assay, from the lowest: compound 3; then compound 2; then compound 1. At a limit, above all of these: compound 4.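

In this assay compound 4 gives > 100000 nM, which is a limit of the assay and not a number: the limit of > 100000 nM in this assay, at which 1 of the 4 values shown sits.

Hydrogen in place of butyl on a saturated chain carbon bound to a sulfur, which reads as pentylsulfanyl to methylsulfanyl, gives an at least 6.9-fold higher number from compound 2 to compound 4 (0.84 log units; beyond the scatter), the first measured step at this position in the series. On these data alone, it shows that the chain on the sulfur is not a passive part of compound 2: with the rest of the structure unchanged, losing the butyl portion weakens growth inhibition beyond the scatter, and since one end of the step is a limit, its true size remains unknown.

Only pentyl and methyl are shown at this position, so it stays open whether an ethyl or propyl chain would keep the number of compound 2, and whether a longer chain such as hexyl would lower it further. Also open is what an amine or a carboxylic acid at the end of the chain would do, and why the step goes this way cannot be told from these compounds.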